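A Second Chloro on the Core of Compound 3

A few compounds are considered here, and "the series" means these few. Any claim that something is new, unique, unknown or untested is made for them only; others in the source may bear on it.

Compound 1 `ClCc1ccccc1Cn1cnc2c(Cl)ncnc21`: in a functional assay on SNB-75 cells (Homo sapiens) for cytotoxicity, read by sulforhodamine B assay, with a stated time of 48 h (a higher number here means a weaker inhibitor of growth, a lower number a stronger inhibitor of growth), compound 1 gives 11000 nM.
Compound 2 `ClCc1cccc(Cn2cnc3ncnc(Cl)c32)c1`: in this assay compound 2 gives 3540 nM.
Compound 3 `ClCc1cccc(Cn2cnc3c(Cl)ncnc32)c1`: in this assay compound 3 gives 4570 nM.

The three measured compounds share one core carrying a single chloro, and they differ in how the substituted benzyl group is arranged and attached. Among the three numbers, compound 3 holds the second highest. Its nearest neighbour is compound 2, whose value lies within the scatter of compound 3, so no order between the two can be drawn. Compound 1 is the furthest, with a higher number that lies beyond the scatter.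

Compound 4 `ClCc1cccc(Cn2cnc3c(Cl)nc(Cl)nc32)c1` differs from compound 3 in one place: chloro in place of hydrogen on an aromatic carbon. Within the data shown here, no pair among the measured compounds isolates this change, so the series itself offers no guide to what a second chloro on the core does in this assay. The expected change is therefore set at a 1.1-fold lower number from compound 3 to compound 4 (0.06 log units; within the scatter), an expectation that rests only on compound 3 and its value 4570 nM. Compound 4 is estimated at 4000 nM in this assay, with a range from 1500 nM to 12000 nM.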

Compound 4, concentration for total growth inhibition: 3890 nM
For compound 4 the middle estimate is 1.0-fold (0.01 log units) above the measured one; measured number inside the range.
By their numbers in this assay, from the lowest: compounds 2, 4 and 3 (each within the scatter of the next); then compound 1.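

In this assay, among these compounds, chloro in place of hydrogen on the aromatic carbon between the two ring nitrogen atoms gives a 1.2-fold lower number from compound 3 to compound 4 (0.07 log units; within the scatter), the first step that isolates a single change on the shared core. The earlier compounds shown here carried a single chloro on that core and differed only in the benzyl part, so they said nothing about this position; this pair shows that a second chloro here, on the compound 3 framework, leaves growth inhibition indistinguishable from that of compound 3, and no order can be drawn between the two. No measurement offered here accounts for this result or says what lies behind it.

On these data alone, what remains open is whether this position is equally undemanding for groups other than chloro, such as an amine, a methoxy group or a morpholine ring, any of which could be tested against compound 3 in the same way. As far as these compounds go, it is also open whether a second chloro at this position would give a similar result on the frameworks of compound 1 and compound 2.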